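A few compounds are considered here, and "the series" means these few. Any claim that something is new, unique, unknown or untested is made for them only; others in the source may bear on it.

Series notes. Compound 1 `C=CS(=O)(=O)NC/C=C/c1cc(OC)cc(O)c1C(=O)OC(C)C` has been measured in an assay on isolated protein for inhibition of MAP kinase-interacting serine/threonine-protein kinase 1 (Homo sapiens), tested at 10 uM (on this read-out higher numbers stand for more inhibition at the one concentration tested (going by the name of the read-out) and lower numbers for less inhibition), where compound 1 gives 5.6%. Going by the values given here, the only other measured member, compound 2 `CCN(CC)C/C=C/C(=O)NC/C=C/c1cc(OCCc2ccc(F)cc2)cc(O)c1C(=O)OC(C)C`, gives 7.8% in this assay; the two numbers lie within the usual scatter of each other, so nothing separates compound 1 from compound 2 on this read-out, and both sit near the bottom of the percentage scale. Compound 3 `COc1cc(O)c(C(=O)OC(C)C)c(/C=C/CN2C(=O)C=CC2=O)c1` has not yet been measured. It differs from compound 1 in one place: a group of 7 heavy atoms (4 carbon, 1 nitrogen, 2 oxygen; one five-membered non-aromatic ring with 1 hetero atom) in place of a group of 6 heavy atoms (2 carbon, 1 nitrogen, 2 oxygen, 1 sulfur; no ring), on a saturated chain carbon bound to a double-bonded chain carbon. Among the compounds with values here, no pair of measured compounds differing in a single place is available, so there is no measured step to lean on, and the two measured values both show little inhibition. The step of a number 2.4 percentage points higher from compound 1 to compound 3 (within the scatter) is therefore expected to remain within the scatter, with no clear direction. Compound 3 is estimated at 8%, with a range from -5% to 25%.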

Compound 3, a percentage reported as inhibition, at one concentration (the size of the read-out at that concentration, not a potency): 5.4%
The estimate for compound 3 lay 2.6 percentage points above the measured number; measured number inside the range.
By their numbers in this assay, from the lowest: compounds 3, 1 and 2 (each within the scatter of the next).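

Going by these compounds alone, the exchange of the (vinylsulfonyl)amino group for the group with one five-membered non-aromatic ring, on a saturated chain carbon bound to a double-bonded chain carbon, gives the first single-place comparison: in this assay, a number 0.2 percentage points lower from compound 1 to compound 3 (within the scatter) and stays within the scatter. At this place, neither the new ring nor the absence of a hydrogen-bond donor in the entering group moves the number out of the low range, where compound 3 stands at 5.4% on the percentage scale. Nothing measured here accounts for this flat result.

On these data alone, whether a primary amine, a carboxylic acid or a longer chain at this place would give a number clearly above this low range remains open. Also open, as far as these compounds go, is whether any difference between these two groups would appear at a higher tested concentration.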